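The source may report more compounds than this note shows. Statements on the series, on what has been measured and on what is new or still open speak of the compounds shown alone.

In a functional assay on MV4-11 cells (Homo sapiens) for antiproliferative activity, read by CellTiter-Glo, with a stated time of 72 h (a higher number here means a weaker inhibitor, a lower number a stronger inhibitor), compound 1 `CO[C@@H]1[C@H](N(C)c2ncc(-c3c[nH]c4ccc(Br)cc34)s2)C[C@H]2O[C@]1(C)n1c3ccccc3c3c4c(c5c6cc(Cl)ccc6n2c5c31)C(=O)NC4` gives 430 nM, compound 2 `CO[C@@H]1[C@H](N(C)c2ncc(-c3c[nH]c4ccccc34)s2)C[C@H]2O[C@]1(C)n1c3ccccc3c3c4c(c5c6cc(Br)ccc6n2c5c31)C(=O)NC4` gives 360 nM and compound 3 `CO[C@@H]1[C@H](N(C)c2ncc(-c3c[nH]c4ccc(Cl)cc34)s2)C[C@H]2O[C@]1(C)n1c3ccccc3c3c4c(c5c6cc(Br)ccc6n2c5c31)C(=O)NC4` gives 700 nM. Among the measured compounds shown here, compound 3 carries the highest of the three numbers, though its distances to compound 1 and to compound 2 both fall within the scatter; the one measured step leading to it, a 1.9-fold higher number from compound 2 to compound 3 (0.29 log units; within the scatter), is likewise within the scatter. Compound 4 `CO[C@@H]1[C@H](N(C)c2ncc(-c3c[nH]c4ccc(Br)cc34)s2)C[C@H]2O[C@]1(C)n1c3ccccc3c3c4c(c5c6cc(Br)ccc6n2c5c31)C(=O)NC4` differs from compound 3 by bromo in place of chloro on an aromatic carbon. For the measured compounds named here, no measured step swaps one halogen for another at this position, and the only step that bears on it, a 1.9-fold higher number from compound 2 to compound 3 (0.29 log units; within the scatter), was small. A step of no more than the scatter is therefore expected, so compound 4 is estimated at 550 nM in this assay, within 250 nM to 1200 nM, the expected step being a 1.3-fold lower number from compound 3 to compound 4 (0.10 log units; within the scatter).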

Compound 4, half-maximal inhibitory concentration: 390 nM
The estimate for compound 4 lay 1.4-fold (0.15 log units) above the measured number; the range from low to high includes it.
By their numbers in this assay, from the lowest: compounds 2, 4, 1 and 3 (each within the scatter of the next).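

In this assay, the 5-bromo-1H-indol-3-yl group gives a 1.8-fold lower number from compound 3 to compound 4 (0.25 log units; within the scatter) against 5-chloro-1H-indol-3-yl and a 1.1-fold higher number from compound 2 to compound 4 (0.03 log units; within the scatter) against the indole without a halogen on this carbon, so neither change at this position is resolved from the scatter. Bromo in place of chloro on the other halogen-bearing ring of the shared core, a 1.1-fold lower number from compound 1 to compound 4 (0.04 log units; within the scatter), is also unresolved. No measured data available here account for these steps. From the compounds shown here alone, whether an amine, a carboxylic acid or a longer chain on this aromatic carbon would give a step beyond the scatter stays open.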